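Diaminoquinoxaline series: arylthio replacement, growth inhibition

This account rests on a few compounds, and the source may have more. Where it says the series, first, only, none or still open, it means among the compounds named here.

Measured so far:
compound 1 `Nc1cc(N)c2nc(-c3ccccc3)c(NCc3ccc(F)cc3)nc2c1`; in a functional assay on HCT-116 cells (Homo sapiens) for inhibition, read by sulforhodamine B assay, with a stated time of 48 h (a higher number here means a weaker inhibitor of growth, a lower number a stronger inhibitor of growth), compound 1 gives a limit, < 100000 nM
compound 2 `COc1ccc(Sc2nc3cc(N)cc(N)c3nc2-c2ccccc2)cc1`; in this assay compound 2 gives a limit, < 100000 nM

Compound 2 carries the (4-methoxyphenyl)sulfanyl group on the shared core. Its value in this assay is a limit only, so where it stands among real numbers is not known. For the measured compounds named here, the single step between measured compounds, a step that the two limits leave unreadable from compound 1 to compound 2, cannot be read because both values sit at the limit of < 100000 nM in this assay, at which 2 of the 2 values shown sit.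

Compound 3 `Nc1cc(N)c2nc(-c3ccccc3)c(Sc3ccc(Cl)c(Cl)c3)nc2c1` differs from compound 2 by 3,4-dichlorophenyl in place of 4-methoxyphenyl on a sulfur. Going by the values given here, no measured step touches this change, and no measured step gives a readable size at all. The expectation for this assay therefore rests on the shared core alone: a value somewhere within the limit, with wide uncertainty, and no direction beyond the scatter can be claimed. Compound 3 is estimated at 30000 nM, between 5000 nM and 100000 nM. The step that the limit leaves unreadable from compound 2 to compound 3 is the expected change, taken from the limit as a placeholder, and carries no weight.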

Compound 3, concentration for total growth inhibition: 47900 nM
Compound 3: the middle estimate sits 1.6-fold (0.20 log units) below what was measured; the measured number falls inside the stated range.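

No new step can be read in this assay for compound 3 against compound 1 or compound 2, because those two compounds give only limits: the limit of < 100000 nM in this assay, at which 2 of the 3 values shown sit.

As far as these compounds go, whether (3,4-dichlorophenyl)sulfanyl on the shared core differs in either direction from (4-methoxyphenyl)sulfanyl or (4-fluorobenzyl)amino stays open.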